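The source may report more compounds than this note shows. Statements on the series, on what has been measured and on what is new or still open speak of the compounds shown alone.

Three compounds that share one core and differ in a single group on an aromatic ring have been measured in a functional assay on KB cells (Homo sapiens) for antiproliferative activity, read by sulforhodamine B assay, with a stated time of 3 days; a higher number here means that more compound is needed for the effect, a lower number that less compound is needed. Compound 1 `CCC1=C(O)c2c(oc(-c3ccc(C(C)C)cc3)cc2=O)C(CC)(CC)C1=O`, with isopropyl, gives 8.13 uM. Compound 2 `CCC1=C(O)c2c(oc(-c3ccc(O)cc3)cc2=O)C(CC)(CC)C1=O`, with hydroxy, gives 20.6 uM. Compound 3 `CCC1=C(O)c2c(oc(-c3ccc(OC)cc3)cc2=O)C(CC)(CC)C1=O`, with methoxy, gives 17.7 uM. Compound 3 cannot be told apart from compound 2, with a 1.2-fold lower number from compound 2 to compound 3 (0.07 log units; within the scatter). Both stand above compound 1, with a 2.2-fold higher number from compound 1 to compound 3 (0.34 log units; beyond the scatter) and a 2.5-fold higher number from compound 1 to compound 2 (0.40 log units; beyond the scatter).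

Compound 4 `CCC1=C(O)c2c(oc(-c3ccc(Br)cc3)cc2=O)C(CC)(CC)C1=O` has bromo in place of methoxy on an aromatic carbon. Going by the values given here, no bromo compound has been measured, so the guide is indirect. Hydroxy and methoxy both contain oxygen and give similar numbers, while compound 1, at 8.13 uM, has no oxygen in that group. Bromo has none either, which suggests a move toward compound 1, no larger than those modest steps. The expected change is a 1.6-fold lower number from compound 3 to compound 4 (0.21 log units; within the scatter). For compound 4 the estimated value is 11 uM, with an expected range of 6 uM to 20 uM.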

Compound 4, concentration for half-maximal effect: > 48.1 uM
Compound 4 ended at the assay's limit (the forecaster's own chance of this, stated with the estimate: 3%); at least 4.3-fold (0.64 log units) between middle value and limit.
By their numbers in this assay, from the lowest: compound 1; then compounds 3 and 2 (each within the scatter of the next). At a limit, above all of these: compound 4.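

In this assay compound 4 ended at a limit of the assay and not at a number: the limit of > 48.1 uM in this assay, at which 1 of the 4 values shown sits. The steps can still be read as minimum sizes, with bromo in place of methoxy giving an at least 2.7-fold higher number from compound 3 to compound 4 (0.43 log units; beyond the scatter), bromo in place of hydroxy giving an at least 2.3-fold higher number from compound 2 to compound 4 (0.36 log units; beyond the scatter), and bromo in place of isopropyl giving an at least 5.9-fold higher number from compound 1 to compound 4 (0.77 log units; beyond the scatter). This position on the aromatic ring, para to a large group, therefore does not sort its groups simply by whether they contain oxygen: compound 1 and compound 4 both lack oxygen in that group, yet they stand at the two ends of the series.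

As far as these compounds go, how far beyond the limit compound 4 truly lies remains open, and with it the full size of all three steps. Also open, from the compounds shown here alone, is whether chloro, an amine or a carboxylic acid at this position would fall nearer compound 1 or compound 4.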